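Methyl for ethoxy on the carbonyl carbon of compound 2

A few compounds are considered here, and "the series" means these few. Any claim that something is new, unique, unknown or untested is made for them only; others in the source may bear on it.

Compound 1 `CC(C)(C)c1nc(-c2ccccc2)ncc1-c1ccccc1` and compound 2 `CCOC(=O)Nc1ncc(-c2ccccc2)c(C(C)(C)C)n1` share one core; compound 2 carries (ethoxycarbonyl)amino in place of phenyl on an aromatic carbon. In a functional assay on the whole organism for inhibition, with Rattus norvegicus as the target, with stated times of 1 h and 3.5 h, at a dose of 100 mg/kg by the oral route (on this read-out lower numbers stand for less inhibition and higher numbers for more inhibition at the one dose given (going by the name of the read-out)), compound 1 sits at a limit, < 5%, not a number (the limit of < 5% in this assay, at which 1 of the 2 values shown sits). In this assay compound 2 gives 24%, the only plain number shown. The step of a number at least 19 percentage points higher from compound 1 to compound 2 (beyond the scatter). Compound 3 `CC(=O)Nc1ncc(-c2ccccc2)c(C(C)(C)C)n1` differs from compound 2 by methyl in place of ethoxy on a carbonyl carbon. Within the data shown here, no measured step touches the carbonyl substituent, so nothing can be carried over; the expected step is a number 4 percentage points lower from compound 2 to compound 3 (within the scatter), within the scatter. Compound 3 is therefore estimated at 20%, between 5% and 40%.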

Compound 3, a percentage reported as inhibition, in the whole organism at one dose (the size of the read-out at that dose, not a potency): 29%
The estimate for compound 3 lay 9 percentage points below the measured number; the range from low to high includes it.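

In this assay, methyl in place of ethoxy on a carbonyl carbon gives a number 5 percentage points higher from compound 2 to compound 3 (within the scatter), so this change does not separate the two groups. Acetamido in place of phenyl on an aromatic carbon gives a number at least 24 percentage points higher from compound 1 to compound 3 (beyond the scatter), which shows that a second acylated amino group also exceeds compound 1. That step starts from a limit rather than a number: the limit of < 5% in this assay, at which 1 of the 3 values shown sits.

Open, on these data alone, is whether a longer chain or a dimethylamino group on this carbonyl carbon would shift the read-out beyond the scatter. Also open, as far as these compounds go, is how a free amino group in place of acetamido would read.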